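The source may hold more compounds than are shown below. What is called first, only, known or untested is meant among the compounds shown, and "the series" means these compounds.

Working notes on the series. Compound 1 `CCOC(=O)C(=O)CC(=O)/C=C/c1cn(-c2ccc(O)cc2)c2ccccc12` carries the shared core with a 4-hydroxyphenyl on the aromatic nitrogen. In an assay on isolated protein for inhibition of DNA nucleotidylexotransferase (Homo sapiens), read by scintillation counting, with a stated time of 10 min (a higher number here means a weaker inhibitor, a lower number a stronger inhibitor), compound 1 gives only > 40 uM, which is a limit of the assay rather than a number. Compound 2 `CCOC(=O)C(=O)CC(=O)/C=C/c1cn(-c2ccc(Cl)cc2)c2ccccc12` likewise gives > 40 uM in this assay, again a limit. Compound 3 `CCOC(=O)C(=O)CC(=O)/C=C/c1cn(Cc2ccc(F)cc2)c2ccccc12` gives > 40 uM in this assay, also a limit. Among the measured compounds shown here, the step that the two limits leave unreadable from compound 1 to compound 2 is therefore unreadable, as are a step that the two limits leave unreadable from compound 1 to compound 3 and a step that the two limits leave unreadable from compound 2 to compound 3; the only evidence is the limit of > 40 uM in this assay, at which 3 of the 3 values shown sit.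

Compound 4 `CCOC(=O)C(=O)CC(=O)/C=C/c1cn(Cc2ccc(OC)cc2)c2ccccc12` differs from compound 1 by 4-methoxybenzyl in place of 4-hydroxyphenyl on an aromatic nitrogen. For the measured compounds named here, none of the measured steps gives a readable size, so no direction can be drawn from them; every change made so far at this aromatic nitrogen has left the value at the limit, compounds 2 and 3 included. The step from compound 1 is expected to be a step that the limit leaves unreadable from compound 1 to compound 4, most likely not readable either. Compound 4 is accordingly estimated at 60 uM in this assay, with a range of 20 uM to 200 uM, and a limit remains the most probable report.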

Compound 4, concentration for 50% inhibition: > 40 uM
Compound 4: no number, only a limit; the forecaster's own chance of this, stated with the estimate: 75%; the middle value is on the limit's open side.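

The steps from compounds 1, 2 and 3 to compound 4 cannot be read, since each pair rests on limits rather than numbers: the limit of > 40 uM in this assay, at which 4 of the 4 values shown sit.

The compounds shown leave open how strongly any of them inhibits in this assay, and whether any change on the aromatic nitrogen alters that.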